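Replacing a phenoxy group with a spiro-fused amine: solubility outlook

A few compounds are considered here, and "the series" means these few. Any claim that something is new, unique, unknown or untested is made for them only; others in the source may bear on it.

Compound 1 `COc1ccc2[nH]c(C(=O)N3CC(=O)N(Cc4ccccc4)[C@@H](COc4ccccc4)C3)cc2c1` gives 12200 nM in a physicochemical assay for solubility, read by spectrophotometry, in phosphate buffer, with a stated time of 2 h, at pH 7.4; a higher number here means a more soluble compound, a lower number a less soluble compound.
Compound 2 `COc1ccc2[nH]c(C(=O)N3CC(=O)N(Cc4c[nH]c5ccccc45)[C@@H](Cc4ccccc4)C3)cc2c1` gives 10300 nM in this assay.
Compound 3 `COc1cccc(CN2C(=O)CN(C(=O)c3cc4cc(OC)ccc4[nH]3)C[C@@H]2c2ccccc2)c1` gives 13600 nM in this assay.

Among the three measured numbers, compound 1 stands second highest. Its nearest neighbour is compound 3, whose value is a little higher, and its furthest is compound 2, whose value is a little lower; both gaps lie within the scatter of repeated measurements, so the three compounds cannot be told apart on these numbers.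

Compound 4 `COc1ccc2[nH]c(C(=O)N3CC(=O)N(Cc4ccccc4)[C@@H](CN4CCC5(CCCC5)CC4)C3)cc2c1` has not yet been measured. It differs from compound 1 in one place: a group of 10 heavy atoms (9 carbon, 1 nitrogen; one five-membered non-aromatic ring of carbon only, one six-membered non-aromatic ring with 1 hetero atom) in place of a group of 7 heavy atoms (6 carbon, 1 oxygen; one six-membered aromatic ring of carbon only), on a saturated chain carbon bound to a saturated ring carbon. Among the measured compounds shown here, no step between two measured compounds resembles this change, so nothing in the measured set says how large its effect should be. For the measured compounds named here, the structural change is therefore the only guide.

The estimate for compound 4 in this assay is 30000 nM, with a range from 12000 nM to 80000 nM. This estimate means a step of a 2.5-fold higher number from compound 1 to compound 4 (0.39 log units; beyond the scatter), expected to be upward and somewhat beyond the scatter, though a value no different from compound 1 is not ruled out.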

Compound 4, solubility: 5000 nM
Estimate against measurement, compound 4: 6.0-fold (0.78 log units) above; the whole stated range lies above it.
By their numbers in this assay, from the lowest: compound 4; then compounds 2, 1 and 3 (each within the scatter of the next).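

In this assay, among the compounds shown here, the exchange of the phenoxy group for the spiro-fused amine, on a saturated chain carbon bound to a saturated ring carbon, gives a 2.4-fold lower number from compound 1 to compound 4 (0.39 log units; beyond the scatter) and is the first step in the set that differs in one place. It shows that the number in this assay responds to what this position carries, and that for this change the step runs downward and lies beyond the scatter, though modestly. No measured evidence accounts for the size or direction of this step.

The compounds shown do not separate the part played by the five-membered carbon ring from that of the six-membered ring holding the nitrogen. Going by these compounds, how a smaller amine or a carboxylic acid would read on the same saturated chain carbon also remains open.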